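A few compounds are considered here, and "the series" means these few. Any claim that something is new, unique, unknown or untested is made for them only; others in the source may bear on it.

Measured so far:
- compound 1 `CCc1nc(-c2ccc(Cl)cc2Cl)c(CC)nc1NC(C1CC1)C1CC1` — 0.183 h
- compound 2 `CCc1nc(-c2ccc(OC(F)(F)F)cc2OC)c(OC)nc1NC(CC)CC` — 0.867 h

Working notes. Of the compounds shown here, two on the shared core have been measured in an in vitro ADME assay on microsomes (Homo sapiens) for metabolic stability; a higher number here means that the compound lasts longer, a lower number that the compound disappears faster. Compound 1 `CCc1nc(-c2ccc(Cl)cc2Cl)c(CC)nc1NC(C1CC1)C1CC1` gives 0.183 h in this assay, the lower of the two numbers. Compound 2 `CCc1nc(-c2ccc(OC(F)(F)F)cc2OC)c(OC)nc1NC(CC)CC` gives 0.867 h, a gap that lies beyond the usual scatter; the two compounds differ at several places, so no single change can be read from that gap.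

The next step is compound 3 `CCc1nc(-c2ccc(Cl)cc2Cl)c(CC)nc1SC(C)CC`, which keeps everything of compound 1 except one substituent: (sec-butyl)sulfanyl in place of (dicyclopropylmethyl)amino on an aromatic carbon. Among the measured compounds shown here, no measured pair isolates this kind of change, so the direction is open. With nothing in the measured pairs to point either way, the expectation for the step of a 1.1-fold higher number from compound 1 to compound 3 (0.04 log units; within the scatter) is one of no size beyond the scatter, in either direction. Compound 3 is therefore expected near 0.2 h in this assay, within a range of 0.08 h to 0.5 h.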

Compound 3, half-life: 0.283 h
Compound 3: the middle estimate sits 1.4-fold (0.15 log units) below what was measured; the measured number falls inside the stated range.
By their numbers in this assay, from the lowest: compounds 1 and 3 (each within the scatter of the next); then compound 2.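

At the aromatic carbon next to the ring nitrogen and para to the 2,4-dichlorophenyl group, (sec-butyl)sulfanyl in place of (dicyclopropylmethyl)amino gives a 1.5-fold higher number from compound 1 to compound 3 (0.19 log units; within the scatter) in this assay. Among the compounds shown here, this is the first pair that differs in one place, and its half-lives are not separated, although the exchange takes out both three-membered rings and the hydrogen-bond donor of the amino group. Nothing at hand explains this step.

On these data alone, whether the linking atom or the attached alkyl group matters at this position remains open, and a (sec-butyl)amino group on the core of compound 1 would separate the two. A sec-butoxy group there would extend the comparison to an ether oxygen as the linking atom.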